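The compounds below may be only part of what the source reports. "The series", "measured", "known", "first", "only" and "open" are said of these compounds alone.

Compound 1 `CC(=O)Nc1ccc2oc(-c3cccc(F)c3)c(O)c(=O)c2c1` and compound 2 `CC(=O)Nc1ccc2oc(-c3ccc(F)cc3)c(O)c(=O)c2c1` share one core. In an ADME assay on THP-1 cells (Homo sapiens) for cytotoxicity, read by flow cytometry and propidium iodide staining, with a stated time of 72 h (on this read-out higher numbers stand for weaker inhibition and lower numbers for stronger inhibition), compound 1 gives 36000 nM and compound 2 gives 26000 nM. The change between them, (4-fluorophenyl in place of 3-fluorophenyl on an aromatic carbon), produced a 1.4-fold lower number from compound 1 to compound 2 (0.14 log units; within the scatter). Compound 3 `COc1c(-c2cccc(F)c2)oc2ccc(N)cc2c1=O` sits on a second core; the difference between the two cores is not broken down here. In this assay compound 3 gives 34000 nM, within the scatter of compound 1 and compound 2. Compound 4 `COc1c(-c2ccc(F)cc2)oc2ccc(N)cc2c1=O` carries the same kind of change, (4-fluorophenyl in place of 3-fluorophenyl on an aromatic carbon); the surroundings differ in that the place is ortho to a methoxy group instead of ortho to a hydroxy group. Among the compounds with values here, the step from compound 3 to compound 4 is expected to be a 1.3-fold lower number from compound 3 to compound 4 (0.12 log units; within the scatter), since the one earlier step of a 1.4-fold lower number from compound 1 to compound 2 (0.14 log units; within the scatter) was within the scatter. Compound 4 is expected near 26000 nM, estimated between 12000 nM and 60000 nM.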

Compound 4, half-maximal inhibitory concentration: 36000 nM
Compound 4: the middle estimate sits 1.4-fold (0.14 log units) below what was measured; the range from low to high includes it.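

In this assay, the change to 4-fluorophenyl in place of 3-fluorophenyl gives a 1.1-fold higher number from compound 3 to compound 4 (0.02 log units; within the scatter), and the two cores agree within the scatter: the same change on two cores in this assay, a 1.4-fold lower number (0.14 log units; within the scatter) from compound 1 to compound 2 and a 1.1-fold higher number (0.02 log units; within the scatter) from compound 3 to compound 4, 1.5-fold (0.17 log units) apart, within the scatter of two such steps. On both cores shown, then, this change carries over as a step too small to read. Two pairs do not make a rule for other cores, and with both steps within the scatter, neither their opposite signs nor any preference between the two fluorophenyl groups can be read.

Open, going by these compounds, is whether the same flat result would hold with trifluoromethyl or a carboxylic acid on the phenyl ring in place of fluorine. Also open, on these data alone, is whether it would hold on a core pairing the acetamide with the methoxy group.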